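Chloroacetamide replacements on a shared diaryl core

The source may hold more compounds than are shown below. What is called first, only, known or untested is meant among the compounds shown, and "the series" means these compounds.

Measured compounds:
Compound 1, `Cn1c(-c2ccc(NC(=O)CCl)cc2)nc(-c2ccccc2)c1-c1ccccc1`: 28.7 ug/mL
Compound 2, `Cn1cnnc1SCC(=O)Nc1ccc(-c2nc(-c3ccccc3)c(-c3ccccc3)n2C)cc1`: 10.7 ug/mL
Compound 3, `Cn1c(-c2ccc(NC(=O)CSC3=NCCS3)cc2)nc(-c2ccccc2)c1-c1ccccc1`: 21 ug/mL

In a functional assay on HT-29 cells (Homo sapiens) for cytotoxicity, read by MTT assay, with a stated time of 24 h (on this read-out higher numbers stand for weaker inhibition and lower numbers for stronger inhibition), compound 1 gives the highest of the three numbers. Its nearest neighbour is compound 3, and the two lie within the scatter of one another: a 1.4-fold lower number from compound 1 to compound 3 (0.14 log units; within the scatter). Compound 2 sits further off: a 2.7-fold lower number from compound 1 to compound 2 (0.43 log units; beyond the scatter), a modest step beyond the scatter. Between compound 2 and compound 3 the gap is within the scatter: a 2.0-fold higher number from compound 2 to compound 3 (0.29 log units; within the scatter).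

Compound 4, `CN1CCN(CC(=O)Nc2ccc(-c3nc(-c4ccccc4)c(-c4ccccc4)n3C)cc2)CC1`, is not yet measured. It differs from compound 1 in one place: 4-methylpiperazin-1-yl in place of chloro on a saturated chain carbon bound to a carbonyl carbon. The two measured steps that bear on it both replace chloro on a saturated chain carbon bound to a carbonyl carbon with a larger group, and both lowered the number in this assay, one modestly and one within the scatter. A step of similar size, downward or none beyond the scatter, is therefore expected. This expectation means a 1.6-fold lower number from compound 1 to compound 4 (0.20 log units; within the scatter). Compound 4 is expected to give 18 ug/mL, with a range from 8 ug/mL to 40 ug/mL.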

Compound 4, half-maximal inhibitory concentration: 35.5 ug/mL
For compound 4 the middle estimate is 2.0-fold (0.29 log units) below the measured one; the range from low to high includes it.
By their numbers in this assay, from the lowest: compounds 2, 3, 1 and 4 (each within the scatter of the next, the first and the last beyond it).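

In this assay, 4-methylpiperazin-1-yl on the saturated chain carbon bound to a carbonyl carbon leaves the number where chloro had it (a 1.2-fold higher number from compound 1 to compound 4 (0.09 log units; within the scatter)), so a larger group in place of chloro does not by itself lower the number. It also stays within the scatter of the group in compound 3 (a 1.7-fold higher number from compound 3 to compound 4 (0.23 log units; within the scatter)), but it separates clearly from the (4-methyl-4H-1,2,4-triazol-3-yl)sulfanyl group (a 3.3-fold higher number from compound 2 to compound 4 (0.52 log units; beyond the scatter)), a second modest step beyond the scatter that again involves compound 2. Nothing available accounts for this difference.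

The compounds shown do not separate the part played by the sulfur link in compound 2 from that of its triazole ring. On these data alone, whether a morpholin-4-yl group or a simple dimethylamino group at this carbon would fall with compound 4 or with compound 2 also remains open.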